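A Fluoro Substituent on the Core of Compound 1

A few compounds are considered here, and "the series" means these few. Any claim that something is new, unique, unknown or untested is made for them only; others in the source may bear on it.

Measured compounds:
- compound 1, `COc1ccc(Cn2cc(/C=N\NC(=O)c3c[nH]c4ccccc34)c3ccccc32)cc1`, 12400 nM
- compound 2, `COc1ccc(Cn2cc(/C=N\NC(=O)c3c[nH]c4ccccc34)c3cc(OC)ccc32)cc1`, 15000 nM
- compound 3, `COc1ccc2c(c1)c(/C=N\NC(=O)c1c[nH]c3ccc(Br)cc13)cn2Cc1ccc(Cl)cc1`, 29100 nM

All three were tested in a functional assay on MCF7 cells (Homo sapiens) for cytotoxicity; a higher number here means a weaker inhibitor, a lower number a stronger inhibitor. Among the numbers in hand, compound 1 gives the lowest. Its nearest neighbour is compound 2, whose number lies within the scatter of repeated measurements, so the two cannot be told apart. Compound 3 gives a number that stands beyond the scatter from compound 1, and it also differs from compound 1 in more than one place, so no single change accounts for that gap.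

Compound 4, `COc1ccc(Cn2cc(/C=N\NC(=O)c3c[nH]c4ccccc34)c3ccc(F)cc32)cc1`, has not yet been measured. It differs from compound 1 by one change: fluoro in place of hydrogen on an aromatic carbon. For the measured compounds named here, the only single step recorded is the one from compound 1 to compound 2, where a methoxy replaces a hydrogen on the same fused ring and the result was a 1.2-fold higher number from compound 1 to compound 2 (0.08 log units; within the scatter). On that basis the small fluoro substituent is expected to leave the number in this assay essentially unchanged, with no step beyond the scatter in either direction. Compound 4 is therefore estimated to give 13000 nM, within a range of 6000 nM to 28000 nM, corresponding to an expected step of a 1.0-fold higher number from compound 1 to compound 4 (0.02 log units; within the scatter).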

Compound 4, half-maximal inhibitory concentration: 13100 nM
Beside the measured number, compound 4's estimate is 1.0-fold (0.00 log units) below it; measured number inside the range.
By their numbers in this assay, from the lowest: compounds 1, 4, 2 and 3 (each within the scatter of the next, the first and the last beyond it).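

Measured in this assay the fluoro substituent gives a 1.1-fold higher number from compound 1 to compound 4 (0.02 log units; within the scatter) and so cannot be told apart from the hydrogen it replaces on this aromatic carbon, which is meta to a fused ring and para to a fused ring. The earlier single step, a 1.2-fold higher number from compound 1 to compound 2 (0.08 log units; within the scatter) for a methoxy on another carbon of the core, was also within the scatter, so the core of compound 1 now has two single substitutions that leave the number unresolved from its parent. Nothing in hand bears on the reason for this result.

From the compounds shown here alone, whether this carbon tolerates any substituent or only these two remains open, since a larger or charged group here, such as an amine, a carboxylic acid or a longer alkyl chain, could still move the number beyond the scatter. Going by these compounds, it is also open whether the fluoro would leave the number just as unmoved on a molecule carrying the other changes seen in compound 3, which differs from compound 1 in more than one place.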